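Methyl substitution across two linker variants

The compounds below may be only part of what the source reports. "The series", "measured", "known", "first", "only" and "open" are said of these compounds alone.

Compound 1 `O=c1ccc2ccc(Oc3no[n+]([O-])c3S(=O)(=O)c3ccccc3)cc2o1` and compound 2 `Cc1cc(=O)oc2cc(Oc3no[n+]([O-])c3S(=O)(=O)c3ccccc3)ccc12` form one pair; compound 3 `O=C(COc1ccc2ccc(=O)oc2c1)OCCOc1no[n+]([O-])c1S(=O)(=O)c1ccccc1` and compound 4 `Cc1cc(=O)oc2cc(OCC(=O)OCCOc3no[n+]([O-])c3S(=O)(=O)c3ccccc3)ccc12` form a second pair built on a longer linking chain. The difference between the core of compound 1 and the core of compound 3 is not broken down here.

In a functional assay on HUVEC cells (Homo sapiens) for antiproliferative activity, read by MTT assay, with a stated time of 48 h (on this read-out lower numbers stand for stronger inhibition and higher numbers for weaker inhibition), compound 1 gives 6750 nM and compound 2 gives 5430 nM. The change between them is methyl in place of hydrogen on an aromatic carbon and yields a 1.2-fold lower number from compound 1 to compound 2 (0.09 log units; within the scatter). For compound 3 only a limit is known: in this assay compound 3 returns > 20000 nM, which is the limit of > 20000 nM in this assay, at which 1 of the 3 values shown sits, and not a number.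

Compound 4 differs from compound 3 by methyl in place of hydrogen on an aromatic carbon, the same change as that from compound 1 to compound 2; the place lines of the two changes read identically, and the change occurs twice among the four compounds. The expected step is a step that the limit leaves unreadable from compound 3 to compound 4, resting on the observation that the measured 1.2-fold lower number from compound 1 to compound 2 (0.09 log units; within the scatter) lies within the scatter. Since compound 3 itself gives only a limit, the most likely outcome for compound 4 in this assay is again a limit rather than a number. Compound 4 is nonetheless estimated at 25000 nM, with an expected range from 12000 nM to 60000 nM.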

Compound 4, half-maximal inhibitory concentration: > 20000 nM
Compound 4: no number, only a limit; the forecaster's own chance of this, stated with the estimate: 75%; the middle value does not contradict the limit.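

In this assay compound 4 returns > 20000 nM, a limit and not a number. Going by these compounds alone, compound 3 returns > 20000 nM, also a limit, so no step from compound 3 to compound 4 can be read. The compounds shown leave open what methyl in place of hydrogen on an aromatic carbon does on the longer linking chain, where neither compound has a number.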